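Indolyl oxamide series: oxolanylmethyl in place of butyl

The source may hold more compounds than are shown below. What is called first, only, known or untested is meant among the compounds shown, and "the series" means these compounds.

Measured compounds:
- compound 1 `CCCCn1cc(C(=O)C(=O)Nc2ccc(OC)nc2)c2ccccc21`: 18 nM
- compound 2 `COc1ccc(NC(=O)C(=O)c2cc(C(C)C)n3ccccc23)cn1`: 160 nM
- compound 3 `COCCc1cc(C(=O)C(=O)Nc2ccc(OC(F)(F)F)cc2)c2ccccn12`: 758 nM

All three were run in a functional assay on FaDu cells (Homo sapiens) for cytotoxicity, read by MTT assay, with a stated time of 72 h; on this read-out lower numbers stand for higher toxicity in this test and higher numbers for lower toxicity in this test. On this read-out compound 1 gives 18 nM, the lowest of the three numbers, and both its gaps lie beyond the scatter: compound 2 gives 160 nM and compound 3 gives 758 nM. Compound 1 is thus the most cytotoxic of the measured set on these numbers. Compounds 2 and 3 differ from compound 1 in more than one place, so nothing can be said of the single features that separate them.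

The unmeasured compound 4 `COc1ccc(NC(=O)C(=O)c2cn(CC3CCCO3)c3ccccc23)cn1` keeps the core of compound 1 and changes only the chain on the aromatic nitrogen: oxolan-2-yl in place of propyl on a saturated chain carbon bound to an aromatic nitrogen

For the measured compounds named here, no step between two measured compounds isolates a change at this chain, so there is no measured precedent to lean on. The oxamide and the methoxypyridinyl amine of compound 1 are kept, and the change is confined to a saturated chain carbon bound to an aromatic nitrogen. The expectation is therefore a step of at most modest size in this assay, more likely towards a somewhat higher number than a lower one, and possibly none beyond the scatter.

Compound 4 is estimated at 35 nM, with a range from 10 nM to 120 nM. This estimate means an expected step of a 1.9-fold higher number from compound 1 to compound 4 (0.29 log units; within the scatter).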

Compound 4, concentration lethal to 50% of the cells: 31 nM
Compound 4: middle estimate off by 1.1-fold (0.05 log units), on the high side, within the range that was stated.
By their numbers in this assay, from the lowest: compounds 1 and 4 (each within the scatter of the next); then compound 2; then compound 3.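

In this assay the chain on the aromatic nitrogen now has its first comparison that differs in one place: oxolan-2-yl in place of propyl on a saturated chain carbon bound to an aromatic nitrogen gives a 1.7-fold higher number from compound 1 to compound 4 (0.24 log units; within the scatter) and so butyl and (oxolan-2-yl)methyl cannot be told apart on this read-out. On the core of compound 1, this place therefore takes a five-membered non-aromatic ring with a hetero atom and a hydrogen-bond acceptor, with more heavy atoms than propyl, without a step beyond the scatter. No measurement in hand explains this outcome.

Left open is whether the ring oxygen of oxolan-2-yl has any bearing on the read-out, a question for the all-carbon cyclopentylmethyl chain on the same nitrogen, and how far this place extends to a longer chain or to a chain ending in an amine or a carboxylic acid. The compounds shown also leave open whether the same exchange gives a similar step on other cores, since compounds 2 and 3 offer no matching pair.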